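The compounds below may be only part of what the source reports. "The series", "measured", "known", "first", "only" and "open" are said of these compounds alone.

Three related compounds have so far been measured in a functional assay on HepG2 cells (Homo sapiens) for inhibition, read by MTT assay, with a stated time of 72 h; on this read-out lower numbers stand for stronger inhibition and higher numbers for weaker inhibition. Compound 1 `Cc1cccc(-n2cc(COc3cccc(NC(=O)Nc4ccc(Cl)c(C(F)(F)F)c4)c3)nn2)c1` gives 7270 nM, compound 2 `O=C(Nc1cccc(OCc2cn(-c3cccc(Cl)c3)nn2)c1)Nc1ccc(Cl)c(C(F)(F)F)c1` gives 2020 nM, and compound 3 `O=C(Nc1cccc(OCc2cn(-c3ccccc3I)nn2)c1)Nc1ccc(Cl)c(C(F)(F)F)c1` gives 2870 nM. Compound 3 thus stands second highest of the three numbers: its gap to compound 2 lies within the scatter, while compound 1 sits higher by a margin that does not, as the step of a 2.5-fold lower number from compound 1 to compound 3 (0.40 log units; beyond the scatter) shows. The step of a 3.6-fold lower number from compound 1 to compound 2 (0.56 log units; beyond the scatter) is the largest change seen, and a 1.4-fold higher number from compound 2 to compound 3 (0.15 log units; within the scatter) the smallest.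

Compound 4 `O=C(Nc1cccc(OCc2cn(-c3cccc(C(F)(F)F)c3)nn2)c1)Nc1ccc(Cl)c(C(F)(F)F)c1` has not yet been measured. It differs from compound 3 in one place: 3-(trifluoromethyl)phenyl in place of 2-iodophenyl on an aromatic nitrogen. All three measured steps concern the same aromatic ring on that nitrogen, and each moved the number by a modest amount at most. The group entering compound 4 is a 3-substituted phenyl like those of compound 1 and compound 2, and the values of those two compounds enclose the value of compound 3. Going by the values given here, no measured step leads to a trifluoromethyl group on this ring, so the direction cannot be read from the data. The expected step of a 1.1-fold lower number from compound 3 to compound 4 (0.06 log units; within the scatter) is therefore small and within the scatter. Compound 4 is estimated at 2500 nM, with a range from 900 nM to 7000 nM.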

Compound 4, half-maximal inhibitory concentration: 1270 nM
For compound 4 the middle estimate is 2.0-fold (0.29 log units) above the measured one; the range from low to high includes it.
By their numbers in this assay, from the lowest: compounds 4, 2 and 3 (each within the scatter of the next, the first and the last beyond it); then compound 1.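

Trifluoromethyl on this ring gives a 5.7-fold lower number from compound 1 to compound 4 (0.76 log units; beyond the scatter), the largest step yet seen in this assay, and the swap of 2-iodophenyl for 3-(trifluoromethyl)phenyl gives a 2.3-fold lower number from compound 3 to compound 4 (0.35 log units; beyond the scatter), so this ring change now separates two compounds by more than the scatter, which the earlier step between 2-iodophenyl and 3-chlorophenyl did not do. Against that, trifluoromethyl in place of chloro gives a 1.6-fold lower number from compound 2 to compound 4 (0.20 log units; within the scatter), so these two groups cannot be told apart here, and both stand clearly apart from methyl at the same place on the ring. Nothing available explains why the number moves with these groups.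

Because 2-iodophenyl and 3-(trifluoromethyl)phenyl differ in both the group and its place on the ring, the compounds shown cannot say which of the two matters, and a 3-iodophenyl would be needed to separate them. Going by these compounds, it also remains open how this ring would behave with a methoxy group, an amine or a carboxylic acid in the same place, or with no group on it at all, and all the changes so far leave the rest of the shared core untouched.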